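Fluoro in Place of Hydrogen on the Anilino Ring

The source may hold more compounds than are shown below. What is called first, only, known or untested is meant among the compounds shown, and "the series" means these compounds.

compound 1, `COc1cccc(NC2=CC(=O)c3c(nc4n3[C@H]3OC[C@@H](O)[C@H]3OC4)C2=O)c1`: 3830 nM
compound 2, `O=C1C=C(Nc2ccccc2)C(=O)c2c1nc1n2[C@H]2OC[C@@H](O)[C@H]2OC1`: > 4000 nM

In a functional assay on MCF7 cells (Homo sapiens) for inhibition, read by sulforhodamine B assay (on this read-out lower numbers stand for stronger inhibition and higher numbers for weaker inhibition), compound 1 gives 3830 nM. For compound 2 the assay reports only a limit, > 4000 nM. Compound 2 thus sits at the limit of > 4000 nM in this assay, at which 1 of the 2 values shown sits, and how far beyond that limit it lies is not told by the numbers. Within the data shown here, no step between two measured compounds is available here, so no measured pair shows the size of any single change.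

Compound 3, `O=C1C=C(Nc2ccccc2F)C(=O)c2c1nc1n2[C@H]2OC[C@@H](O)[C@H]2OC1`, has not yet been measured in this assay. It differs from compound 2 by fluoro in place of hydrogen on an aromatic carbon. The shared core is kept; the anilino group is kept; only the fluoro is new.

Because compound 2 sits at the limit of > 4000 nM in this assay, at which 1 of the 2 values shown sits, the starting point itself is uncertain. The estimate for compound 3 is placed near the limit: compound 3 is expected to give 4000 nM, somewhere between 1500 nM and 10000 nM. The expected step of a number no higher from compound 2 to compound 3 (the limit leaves the size open) is meant as none beyond the scatter, in neither direction, with a fair chance that the assay again returns only a limit for compound 3.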

Compound 3, half-maximal inhibitory concentration: 3640 nM
Beside the measured number, compound 3's estimate is 1.1-fold (0.04 log units) above it; measured number inside the range.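

Among these compounds, compound 3 gives the first step that can be read at this position: fluoro in place of hydrogen on an aromatic carbon, ortho to a large group, gives an at least 1.0-fold lower number from compound 2 to compound 3 (0.04 log units; that floor lies within the scatter) in this assay. With this fluoro in place, the assay returns a measured number and not a limit, as compound 3 gives 3640 nM, so the read-out now has a firm value for an anilino ring carrying this one new atom. Compound 2 stands only at a limit of the assay, so the true size of the step remains unknown, and the small floor printed with it does not fix how large the change is: the limit of > 4000 nM in this assay, at which 1 of the 3 values shown sits.

On these data alone, whether a chloro, a methyl, an amine or a carboxylic acid in the same place would give a number different from that of the fluoro remains open. The compounds shown also leave open what a fluoro would do elsewhere on the anilino ring, and whether a second fluoro on that ring would move the number beyond the usual scatter.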